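Trimming the pyrazole substituent on a glucagon receptor antagonist

The source may hold more compounds than are shown below. What is called first, only, known or untested is meant among the compounds shown, and "the series" means these compounds.

Two compounds share one core and differ only in the five-membered ring attached to the outer aromatic ring. Compound 1 `CCCC(Oc1ccc(-n2cc(C(=O)N(C)C)cn2)cc1)c1ccc(C(=O)NCCC(=O)O)cc1` carries a dimethylcarboxamide on that ring and in an assay on cells for displacement of a labelled ligand from Glucagon receptor (Homo sapiens), in the presence of a further agent that is not named here (a lower number here means a stronger inhibitor, a higher number a weaker inhibitor), compound 1 gives 6500 nM. Within the data shown here, compound 2 `CCCC(Oc1ccc(-n2cc3c(n2)CCCC3)cc1)c1ccc(C(=O)NCCC(=O)O)cc1` carries instead a fused six-membered non-aromatic ring, and in this assay compound 2 gives 690 nM, the lowest number of the two; the step of a 9.4-fold lower number from compound 1 to compound 2 (0.97 log units; beyond the scatter) is the only measured step and the only one that bears on the new change. Compound 3 `CCCC(Oc1ccc(-n2cc(Cl)cn2)cc1)c1ccc(C(=O)NCCC(=O)O)cc1` replaces that fused ring with a chlorine atom: a group of 6 heavy atoms (3 carbon, 2 nitrogen, 1 chlorine; one five-membered aromatic ring with 2 hetero atoms) in place of a group of 9 heavy atoms (7 carbon, 2 nitrogen; one five-membered aromatic ring with 2 hetero atoms, one six-membered non-aromatic ring of carbon only), on an aromatic carbon. Among the measured compounds shown here, no measured compound shows what a single chlorine does here, so compound 3 is expected to fall between its two neighbours, a modest rise from compound 2 being the estimate, a 1.7-fold higher number from compound 2 to compound 3 (0.24 log units; within the scatter). The expected value for compound 3 is 1200 nM, within 300 nM to 5000 nM.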

Compound 3, inhibition constant: 1100 nM
Estimate against measurement, compound 3: 1.1-fold (0.04 log units) above; the measured number falls inside the stated range.
By their numbers in this assay, from the lowest: compounds 2 and 3 (each within the scatter of the next); then compound 1.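

In this assay the step of a 1.6-fold higher number from compound 2 to compound 3 (0.20 log units; within the scatter) lies within the scatter, so at this position a single chloro on the pyrazole matches the fused six-membered ring of compound 2 with fewer heavy atoms. The step of a 5.9-fold lower number from compound 1 to compound 3 (0.77 log units; beyond the scatter) lies beyond the scatter, so two different groups, the chloro and the fused ring, now both give lower numbers than the dimethylcarbamoyl group of compound 1. No measurement available here explains these differences.

The compounds shown leave open how a methyl, a bromine or a plain hydrogen at that spot on the pyrazole would compare with chloro. They also leave open whether a nitrile or a primary amide would land nearer to compound 1 or to compound 3.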